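This account rests on a few compounds, and the source may have more. Where it says the series, first, only, none or still open, it means among the compounds named here.

Measured in a functional assay on NCI-H1975 cells (Homo sapiens) for inhibition, read by MTT assay, with a stated time of 72 h; a higher number here means a weaker inhibitor, a lower number a stronger inhibitor:

- Compound 1 `FC(F)(F)c1ccc(CSc2nc(N3CCN(c4ccccn4)CC3)cc(C(F)(F)F)n2)cc1`: 17400 nM
- Compound 2 `FC(F)(F)c1ccc(CSc2nc(N3CCN(c4ncccn4)CC3)cc(C(F)(F)F)n2)cc1`: 18300 nM
- Compound 3 `FC(F)(F)c1ccc(CSc2nc(Sc3ncccn3)cc(C(F)(F)F)n2)cc1`: 14000 nM

Compound 3, at 14000 nM, stands within the scatter of both compound 1 and compound 2, so the three values form one tight group and none can be ranked ahead of the others. Compound 4 `Cc1nnc(Sc2cc(C(F)(F)F)nc(SCc3ccc(C(F)(F)F)cc3)n2)s1` departs from compound 3 in one place, with 5-methyl-1,3,4-thiadiazol-2-yl in place of pyrimidin-2-yl on a sulfur. For the measured compounds named here, no measured compound carries the entering group, so the evidence is indirect. Going by the values given here, the only measured single-place step, a 1.1-fold higher number from compound 1 to compound 2 (0.02 log units; within the scatter), exchanges one aromatic ring for another on an amine nitrogen in a ring, and it stays within the scatter. That step lies at a different place, so it offers only modest support. The expected result in this assay is therefore no change beyond the scatter, in either direction, and the expected step is no change at the digits printed from compound 3 to compound 4 (within the scatter). For compound 4 the estimate is 14000 nM, with an expected range from 6000 nM to 30000 nM.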

Compound 4, half-maximal inhibitory concentration: 3060 nM
For compound 4 the middle estimate is 4.6-fold (0.66 log units) above the measured one; the whole stated range lies above it.
By their numbers in this assay, from the lowest: compound 4; then compounds 3, 1 and 2 (each within the scatter of the next).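

In this assay, for the compounds shown here, the group on this sulfur is the first place where a single change moves the number beyond the scatter, with a 4.6-fold lower number from compound 3 to compound 4 (0.66 log units; beyond the scatter), whereas a 1.1-fold higher number from compound 1 to compound 2 (0.02 log units; within the scatter) stayed within it at a different place. The group's heavy-atom count stays at 6, so this shift goes with exchanging a six-membered aromatic ring for a five-membered one that carries a methyl, not with a change in that count. Nothing shown bears on why the number moves.

Compound 4 brings in the 1,3,4-thiadiazole ring and its methyl together, so the compounds shown do not separate the two; the open comparisons are the thiadiazol-2-yl group with hydrogen, an amine or an ethyl group in the methyl's place. As far as these compounds go, whether the step would hold on a different core also remains open.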